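A few compounds are considered here, and "the series" means these few. Any claim that something is new, unique, unknown or untested is made for them only; others in the source may bear on it.

Measured so far in an assay on isolated protein for agonist activity at prostaglandin E2 receptor EP2 subtype (Homo sapiens); on this read-out higher numbers stand for an effect only at larger amounts of compound and lower numbers for an effect already at smaller amounts:
compound 1 `CCCCC1([C@H](O)/C=C/[C@H]2COC(=O)N2CCSc2nc(C(=O)O)cs2)CCC1`: 2.9 nM
compound 2 `CCCCC(C)(C)[C@H](O)/C=C/[C@H]1CCC(=O)N1CCSc1nc(C(=O)O)cs1`: 0.91 nM

Compound 1 stands at the higher of the two numbers. Compound 2 gives 0.91 nM, a lower number, and the gap between the two lies beyond the scatter; compound 2 differs from compound 1 in several places at once, so no single step can be read from this pair.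

Compound 3 `CC(C)(C)CCC1([C@H](O)/C=C/[C@H]2COC(=O)N2CCSc2nc(C(=O)O)cs2)CCC1` has not been measured. It differs from compound 1 in one place: tert-butyl in place of ethyl on a saturated chain carbon, two bonds along the chain from a saturated ring carbon. Within the data shown here, no measured pair isolates this change, so nothing among the two measured compounds says which way it goes. The expected step is small, a 1.3-fold lower number from compound 1 to compound 3 (0.10 log units; within the scatter), towards a somewhat lower number if anything, and it may well stay within the scatter. Compound 3 is accordingly estimated at 2.3 nM, with a range from 0.7 nM to 8 nM.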

Compound 3, half-maximal effective concentration: 3700 nM
Beside the measured number, compound 3's estimate is 1600-fold (3.21 log units) below it; measured number above the stated range.
By their numbers in this assay, from the lowest: compound 2; then compound 1; then compound 3.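

In this assay this position proves far from tolerant: tert-butyl in place of ethyl on a saturated chain carbon, two bonds along the chain from a saturated ring carbon, gives a 1300-fold higher number from compound 1 to compound 3 (3.11 log units; beyond the scatter). On the core of compound 1, then, the butyl chain goes with a low number, while butyl to 3,3-dimethylbutyl is a change this core does not absorb. Nothing at hand bears on what lies behind a step of this size.

On these data alone, whether the loss comes with the greater chain size or with the branching at the chain end stays open; a straight hexyl chain and a 3-methylbutyl chain at this place would separate the two. Also open, as far as these compounds go, is whether the same change would cost as much on the core of compound 2.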